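The source may report more compounds than this note shows. Statements on the series, on what has been measured and on what is new or still open speak of the compounds shown alone.

Measured in a functional assay on CCRF-CEM cells (Homo sapiens) for inhibition; a lower number here means a stronger inhibitor, a higher number a weaker inhibitor:
- Compound 1 `O=C1CCCCC/C1=C\c1ccccc1`: 110000 nM
- Compound 2 `O=C1CCCCC/C1=C\c1ccc(F)cc1`: 198000 nM

For the measured compounds named here, compound 1 has only one measured neighbour, and the two values lie within the scatter of each other, so neither stands clearly apart. Compound 3 `O=C1CCCCC/C1=C\c1cccc(Cl)c1` has not yet been measured. It keeps the core of compound 1, with chloro in place of hydrogen on an aromatic carbon, meta to a group of 9 heavy atoms (chloro in place of hydrogen on an aromatic carbon).

Going by the values given here, the only measured step that bears on this change is the swap of hydrogen for fluoro, a 1.8-fold higher number from compound 1 to compound 2 (0.26 log units; within the scatter). That is a single example with a different group, so it is only a modest guide. It gives no reason to expect a step beyond the scatter in this assay, in either direction. The expected change is a 1.1-fold higher number from compound 1 to compound 3 (0.04 log units; within the scatter). For compound 3 the estimated value is 120000 nM, with an expected range from 55000 nM to 260000 nM.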

Compound 3, half-maximal inhibitory concentration: 40500 nM
The estimate for compound 3 lay 3.0-fold (0.47 log units) above the measured number; measured number outside the range, below it.
By their numbers in this assay, from the lowest: compound 3; then compounds 1 and 2 (each within the scatter of the next).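

In this assay, chloro in place of hydrogen on this aromatic carbon, meta to a group of 9 heavy atoms, gives a 2.7-fold lower number from compound 1 to compound 3 (0.43 log units; beyond the scatter), the first step among these compounds to go beyond the scatter. For the compounds shown here, the earlier swap of hydrogen for fluoro, a 1.8-fold higher number from compound 1 to compound 2 (0.26 log units; within the scatter), stayed within the scatter, so this result is the first sign that a change on the aromatic ring of compound 1 can shift the number, though it rests on a single pair. Nothing measured here explains why chloro lowers the number.

The compounds shown do not separate the effect of the group from that of its place, as none carries fluoro on this carbon or chloro on another. On these data alone, it also remains open whether methoxy, trifluoromethyl or an amine on this carbon would lower the number further or raise it.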